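The compounds below may be only part of what the source reports. "The series", "measured", "known", "first", "only" and "open" are said of these compounds alone.

Measured compounds:
compound 1, `COc1ccc(C(=O)/C=C/c2cc(-c3cc(OC)c(OC)c(OC)c3)n[nH]2)cc1OC` — 87%
compound 2, `COc1cc(-c2cc(/C=C/C(=O)c3ccc(F)c(F)c3)[nH]n2)cc(OC)c1OC` — 86%

In a functional assay on UO-31 cells (Homo sapiens) for cytotoxicity, read by sulforhodamine B assay, with a stated time of 48 h, tested at 0.1 uM (a higher number here means a weaker effect of the compound at the concentration tested, a lower number a stronger effect), compound 1 gives 87%, the higher of the two numbers shown; compound 2 gives 86%, and the single measured step, a number 1 percentage points lower from compound 1 to compound 2 (within the scatter), lies within the scatter, so the two compounds cannot be ranked against each other.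

Compound 3, `COc1cc(C(=O)/C=C/c2cc(-c3cc(OC)c(OC)c(OC)c3)n[nH]2)cc(OC)c1OC`, is not yet measured. It differs from compound 1 by one change: methoxy in place of hydrogen on an aromatic carbon. The exchange makes the ring on the carbonyl carbon a trimethoxyphenyl, the same pattern that the shared core already carries on its other aryl ring.

For the measured compounds named here, no measured step swaps a hydrogen for a methoxy on that ring. Going by the values given here, the only step available, a number 1 percentage points lower from compound 1 to compound 2 (within the scatter), concerns the same ring but a different exchange, and it produced no movement beyond the scatter. On that basis a step of about a number 2 percentage points lower from compound 1 to compound 3 (within the scatter) is expected in this assay, that is, none beyond the scatter. For compound 3 a value near 85% is estimated, with a range from 65% to 100%.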

Compound 3, a percentage reported as activity, at one concentration (the size of the read-out at that concentration, not a potency): 90%
Compound 3: middle estimate off by 5 percentage points, on the low side, and the stated range covers the measured number.
By their numbers in this assay, from the lowest: compounds 2, 1 and 3 (each within the scatter of the next).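

In this assay the step for methoxy in place of hydrogen on an aromatic carbon, ortho to a methoxy group and meta to a large group, reads a number 3 percentage points higher from compound 1 to compound 3 (within the scatter) and so shows that this position on the ring on the carbonyl carbon takes the added methoxy with no shift that can be told from the scatter. The earlier step (a number 1 percentage points lower from compound 1 to compound 2 (within the scatter)) exchanged the substituents on the same ring for fluorine, so two different kinds of change on this ring have now been seen, and neither goes beyond the scatter at this single test concentration. Nothing given here bears on why this position responds as it does.

As far as these compounds go, it remains open whether an amine or a carboxylic acid at this position, in place of the methoxy, would take the number beyond the scatter from compound 1. Also open, from the compounds shown here alone, is whether a change on the other aryl ring of the shared core, which stays trimethoxyphenyl in all three compounds, would move the number at all.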